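Allyloxy for benzyloxy in a weakly active series

The source may hold more compounds than are shown below. What is called first, only, known or untested is meant among the compounds shown, and "the series" means these compounds.

Compound 2 `COc1ccc(C(OCc2ccccc2)c2cccc3ccccc23)c(OC)c1OC` gives only a limit in a functional assay on MDA-MB-231 cells (Homo sapiens) for inhibition, read by sulforhodamine B assay, with a stated time of 48 h (a higher number here means a weaker inhibitor, a lower number a stronger inhibitor), > 20000 nM. Its neighbour compound 1 `COc1ccc(C(c2ccccc2O)c2cccc3ccccc23)c(OC)c1OC` gives 17700 nM, and compound 3 `CCOC(=O)CO/N=C(/c1ccc(OC)c(OC)c1OC)c1cccc2ccccc12` gives 16400 nM. For the measured compounds named here, the one step among the measured compounds, an at least 1.1-fold higher number from compound 1 to compound 2 (0.05 log units; that floor lies within the scatter), rests on a different exchange. Compound 4 `C=CCOC(c1ccc(OC)c(OC)c1OC)c1cccc2ccccc12` differs from compound 2 by vinyl in place of phenyl on a saturated chain carbon bound to an oxygen on a saturated carbon. Going by the values given here, no measured step shows a vinyl-for-phenyl exchange, so the outlook for this step rests on where compound 2 already sits, at the limit of > 20000 nM in this assay, at which 1 of the 3 values shown sits. The step from compound 2 to compound 4 is therefore expected to be small, with no direction beyond the scatter. Compound 4 is expected at 25000 nM with a range from 10000 nM to 60000 nM. That expectation means a step that the limit leaves unreadable from compound 2 to compound 4.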

Compound 4, half-maximal inhibitory concentration: > 20000 nM
Compound 4 ended at the assay's limit; the forecaster's own chance of this, stated with the estimate: 55%; the middle value is on the limit's open side.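

In this assay compound 4 gives > 20000 nM, which is a limit, so allyloxy, like benzyloxy, yields no number at this position. The step between compound 2 and compound 4 cannot be read, and the only readable one is an at least 1.1-fold higher number from compound 1 to compound 4 (0.05 log units; that floor lies within the scatter). The smaller vinyl group in place of phenyl therefore brings no value back into the readable range, and limits now recur in the series: the limit of > 20000 nM in this assay, at which 2 of the 4 values shown sit.

Going by these compounds, how far compound 2 and compound 4 lie beyond the limit remains open. So does whether an amine or a carboxylic acid in this chain would give a readable value.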